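A 2-chlorophenyl analogue of three inactive compounds

A few compounds are considered here, and "the series" means these few. Any claim that something is new, unique, unknown or untested is made for them only; others in the source may bear on it.

Compound 1, `CCOC(=O)c1c(C)[nH]c(=O)c(C#N)c1-c1ccc(C)cc1`, gives in a functional assay on SK-OV-3 cells (Homo sapiens) for inhibition, read by MTT assay, with a stated time of 24 h (on this read-out lower numbers stand for stronger inhibition and higher numbers for weaker inhibition), only a limit, > 100000 nM.
Compound 2, `CCOC(=O)c1c(C)[nH]c(=O)c(C#N)c1-c1ccc(OC)cc1`, gives in this assay only a limit, > 100000 nM.
Compound 3, `CCOC(=O)c1c(C)[nH]c(=O)c(C#N)c1-c1ccc(C#N)cc1`, gives in this assay only a limit, > 100000 nM.

All three compounds share one core and differ only in the group on the phenyl ring. Compound 1 stands at the limit of this assay, as do the other two. The steps among them, a step that the two limits leave unreadable from compound 1 to compound 2, a step that the two limits leave unreadable from compound 1 to compound 3 and a step that the two limits leave unreadable from compound 2 to compound 3, have no readable size, since every value shown sits at the limit of > 100000 nM in this assay, at which 3 of the 3 values shown sit.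

Compound 4, `CCOC(=O)c1c(C)[nH]c(=O)c(C#N)c1-c1ccccc1Cl`, differs from compound 1 in one place: 2-chlorophenyl in place of 4-methylphenyl on an aromatic carbon. The three measured steps, all unreadable in size, give no direction for this change and bear on it only by showing that three variations of the phenyl ring left the compound at the limit. Compound 4 is therefore expected to report a limit as well, with an estimate of 150000 nM, ranging from 50000 nM to 500000 nM. The expected step that the limit leaves unreadable from compound 1 to compound 4 is none beyond the scatter.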

Compound 4, half-maximal inhibitory concentration: > 100000 nM
Compound 4 was reported as a limit; the forecaster's own chance of this, stated with the estimate: 85%; the middle value does not contradict the limit.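

Compound 4, like compound 1, gives only a limit in this assay, so no step between compound 1 and compound 4 can be read: the limit of > 100000 nM in this assay, at which 4 of the 4 values shown sit.

The compounds shown leave open whether any group on the phenyl ring, or any change to the shared core, gives a measurable inhibition.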